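The compounds below may be only part of what the source reports. "The series", "measured", "known", "first", "only" and "open" are said of these compounds alone.

Series notes. Among the measured compounds shown here, compound 2 `Cc1ncc([N+](=O)[O-])n1CCSc1nnc(-c2ccccc2O)o1` gives the highest of the two numbers measured so far in a functional assay on MCF7 cells (Homo sapiens) for cytotoxicity, read by MTT assay, with a stated time of 48 h (on this read-out lower numbers stand for stronger inhibition and higher numbers for weaker inhibition), where compound 2 gives 28300 nM; its nearest neighbour is compound 1 `COc1ccccc1-c1nnc(SCCn2c([N+](=O)[O-])cnc2C)o1`, which in this assay gives 10800 nM. For the measured compounds named here, the one measured step is a 2.6-fold higher number from compound 1 to compound 2 (0.42 log units; beyond the scatter). Compound 3 `Cc1ncc([N+](=O)[O-])n1CCSc1nnc(-c2ccnc(Cl)c2)o1` is not yet measured; compared with compound 2 the change is 2-chloropyridin-4-yl in place of 2-hydroxyphenyl on an aromatic carbon. Going by the values given here, only the step from compound 1 to compound 2 concerns the same aromatic carbon, and it was modest; the present change is of a different kind, so that step gives no direction for it. The expectation for compound 3 can therefore be no more than a move that may reach beyond the scatter either way, with the middle placed near the two measured numbers. The estimate for compound 3 in this assay is 15000 nM, within 5000 nM to 45000 nM, which means a step of a 1.9-fold lower number from compound 2 to compound 3 (0.28 log units; within the scatter) is expected.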

Compound 3, half-maximal inhibitory concentration: 40500 nM
Estimate against measurement, compound 3: 2.7-fold (0.43 log units) below; the range from low to high includes it.
By their numbers in this assay, from the lowest: compound 1; then compounds 2 and 3 (each within the scatter of the next).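

In this assay, 2-chloropyridin-4-yl in place of 2-hydroxyphenyl on this aromatic carbon gives a 1.4-fold higher number from compound 2 to compound 3 (0.16 log units; within the scatter), so exchanging the carbon-only ring with its hydrogen-bond donor for a ring with one hetero atom and no donor does not separate compound 3 from compound 2. The same position with 2-chloropyridin-4-yl in place of 2-methoxyphenyl gives a 3.8-fold higher number from compound 1 to compound 3 (0.57 log units; beyond the scatter), so among these three compounds, 2-methoxyphenyl in compound 1 stands apart, with the lowest number. Nothing measured here bears on the reason for these numbers.

The compounds shown leave open how unsubstituted phenyl or 2-aminophenyl on this carbon would compare with 2-methoxyphenyl, and whether an ethyl group in place of the methyl on that oxygen would keep the number of compound 1. They also leave open whether pyridin-4-yl without the chlorine would stay with compound 3.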